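The source may hold more compounds than are shown below. What is called first, only, known or untested is meant among the compounds shown, and "the series" means these compounds.

Compound 1 `N#Cc1cccc(C(=O)NCN2CCC(c3cccc[n+]3[O-])CC2)c1` carries a 3-cyanophenyl group on its amide carbonyl carbon. In a functional assay on HEK293 cells for agonist activity at D(4) dopamine receptor (Homo sapiens), read by FLIPR (on this read-out higher numbers stand for an effect only at larger amounts of compound and lower numbers for an effect already at smaller amounts), compound 1 gives 840 nM, the highest of the three numbers measured here. Compound 2 `CCOc1cccc(C(=O)NCN2CCC(c3cccc[n+]3[O-])CC2)c1` gives 324 nM, and compound 3 `Cc1cccc(C)c1NC(=O)CN1CCC(c2cccc[n+]2[O-])CC1`, built on a different core, gives 346 nM. Going by the values given here, the one measured step that bears on the next change is a 2.6-fold lower number from compound 1 to compound 2 (0.41 log units; beyond the scatter). Compound 4 `Cc1cc(C(=O)NCN2CCC(c3cccc[n+]3[O-])CC2)ccc1Cl` differs from compound 1 in one place: 4-chloro-3-methylphenyl in place of 3-cyanophenyl on a carbonyl carbon. Again the ring bearing the cyano group is exchanged for an aromatic ring without it, so a modest lowering of the number in this assay is expected, though 4-chloro-3-methylphenyl itself has no measured precedent here. The expected step is a 2.4-fold lower number from compound 1 to compound 4 (0.38 log units; beyond the scatter). For compound 4 the estimate in this assay is 350 nM, within 120 nM to 1000 nM.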

Compound 4, half-maximal effective concentration: 2460 nM
For compound 4 the middle estimate is 7.0-fold (0.85 log units) below the measured one; measured number above the stated range.
By their numbers in this assay, from the lowest: compounds 2 and 3 (each within the scatter of the next); then compound 1; then compound 4.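

In this assay, losing the nitrile does not by itself lower the number: alongside a 2.6-fold lower number from compound 1 to compound 2 (0.41 log units; beyond the scatter) stands a 2.9-fold higher number from compound 1 to compound 4 (0.47 log units; beyond the scatter) for a replacement that also lacks it. On this carbonyl carbon, the two replacements of 3-cyanophenyl therefore move the number in opposite directions, so the group that enters matters as well as the group that leaves. Nothing measured here explains this difference. The compounds shown leave open how chlorine alone or methyl alone on the ring would compare with compound 1. They also leave open where a ring carrying an amine or a carboxylic acid would fall.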